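The source may report more compounds than this note shows. Statements on the series, on what has been measured and on what is new or still open speak of the compounds shown alone.

In a functional assay on HepG2 cells (Homo sapiens) for cytotoxicity, read by MTT assay, with a stated time of 72 h (on this read-out lower numbers stand for stronger inhibition and higher numbers for weaker inhibition), the measured compounds read as follows.
Compound 1 `Cc1cc(=O)n(-c2ccc(F)c(F)c2)nc1C(=O)Nc1ccc(Oc2ncnc3ccsc23)cc1`: 9230 nM.
Compound 2 `Cc1cc(=O)n(-c2ccccc2C(F)(F)F)nc1C(=O)Nc1ccc(Oc2ncnc3sccc23)cc1`: > 40000 nM, a limit of the assay rather than a number.
Compound 3 `Cc1cc(=O)n(-c2ccc(F)cc2)nc1C(=O)Nc1ccc(Oc2ncnc3sccc23)cc1`: 6460 nM.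

Compound 3 and compound 1 lie within the scatter of each other, while compound 2 sits at the limit. Within the data shown here, the only readable step, an at least 6.1-fold lower number from compound 2 to compound 3 (0.79 log units; beyond the scatter), concerns a change of a different kind on the same aromatic ring and offers little direct guidance. Compound 4 `Cc1cc(=O)n(-c2ccc(F)c(F)c2)nc1C(=O)Nc1ccc(Oc2ncnc3sccc23)cc1` differs from compound 3 by fluoro in place of hydrogen on an aromatic carbon. Compound 1 carries the same 3,4-difluorophenyl on a different core, and its value stays within the scatter of compound 3. For compound 4 the expected step is a 1.2-fold higher number from compound 3 to compound 4 (0.09 log units; within the scatter), not beyond the scatter. Compound 4 is thus estimated at 8000 nM, within a range of 3000 nM to 25000 nM.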

Compound 4, half-maximal inhibitory concentration: 16800 nM
Compound 4: middle estimate off by 2.1-fold (0.32 log units), on the low side; low and high end bracket the measured number.
By their numbers in this assay, from the lowest: compounds 3, 1 and 4 (each within the scatter of the next, the first and the last beyond it). At a limit, above all of these: compound 2.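

In this assay, fluoro in place of hydrogen on this aromatic carbon, ortho to a fluoro group, gives a 2.6-fold higher number from compound 3 to compound 4 (0.42 log units; beyond the scatter), so even this small change at this position shifts the reading. Compound 2 reads only as a limit, which leaves an at least 2.3-fold lower number from compound 2 to compound 4 (0.37 log units; beyond the scatter) as a one-sided comparison: the limit of > 40000 nM in this assay, at which 1 of the 4 values shown sits.

With the 3,4-difluorophenyl kept and the group on the oxygen changed, a 1.8-fold higher number from compound 1 to compound 4 (0.26 log units; within the scatter) shows no readable difference.

On these data alone, whether this shift belongs to fluoro alone remains open. A chloro, a methoxy or an amine on the same carbon could tell.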